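The source may hold more compounds than are shown below. What is called first, only, known or untested is meant among the compounds shown, and "the series" means these compounds.

Measured so far in a functional assay on MCF7 cells (Homo sapiens) for inhibition; a higher number here means a weaker inhibitor, a lower number a stronger inhibitor:
Compound 1 `O=C(NO)c1ccc(-c2ccc(CNCCOc3ccccc3)cn2)s1` gives 110 nM.
Compound 2 `Cn1nc(C(F)(F)F)cc1-c1ccc(C(=O)NO)s1` gives 11400 nM.
Compound 3 `O=C(NO)c1ccc(-c2cccs2)s1` reaches only a limit of the assay, > 100000 nM.

Compound 1 holds the lowest of the two numbers shown; compound 2 sits far above it, well beyond the scatter. Compound 3 is recorded only as a limit, (the limit of > 100000 nM in this assay, at which 1 of the 3 values shown sits), and gives no number to compare. For the measured compounds named here, no pair of measured compounds differs in a single place, so no measured step is available to anchor the next change.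

Compound 4 `O=C(NO)c1ccc(-c2ccc(CNCc3ccc(Cl)cc3)cn2)s1` is the compound still to be measured in this assay. It differs from compound 1 in one place: 4-chlorophenyl in place of phenoxymethyl on a saturated chain carbon bound to an amine nitrogen. The shared core of compound 1, with its hydroxamic acid and the amine-bearing chain, is kept. Going by the values given here, with no measured step to lean on, a small step is expected in this assay, either direction, probably not far beyond the scatter. Compound 4 is expected to give about 160 nM, within 40 nM to 650 nM. This estimate means a step of a 1.5-fold higher number from compound 1 to compound 4 (0.16 log units; within the scatter).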

Compound 4, half-maximal inhibitory concentration: 130 nM
For compound 4 the middle estimate is 1.2-fold (0.09 log units) above the measured one; low and high end bracket the measured number.
By their numbers in this assay, from the lowest: compounds 1 and 4 (each within the scatter of the next); then compound 2. At a limit, above all of these: compound 3.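

In this assay, the series now has its first step that can be read at a single place: a 1.2-fold higher number from compound 1 to compound 4 (0.07 log units; within the scatter), with 4-chlorophenyl in place of phenoxymethyl on a saturated chain carbon bound to an amine nitrogen. At this place, the exchange removes the ether oxygen, the one hydrogen-bond acceptor in the leaving group, and brings in chlorine, yet compound 1 and compound 4 remain within the scatter of each other. No measured property in the data bears on this result.

Still open, going by these compounds, is whether the chlorine matters, which a plain phenyl, a fluorine or a methoxy group on the ring could test. It is also unknown how a small methyl, a carboxylic acid or a longer chain at the same place would read in this assay.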